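This account rests on a few compounds, and the source may have more. Where it says the series, first, only, none or still open, it means among the compounds named here.

Series notes. The compounds share one core, shown with compound 1 as `Cc1n[nH]c(C(=O)O)c1Cc1ccc(Oc2ccccc2)cc1`. In an assay on isolated protein for inhibition of 2-Hydroxyacid oxidase 2 (Homo sapiens), tested at 10 uM (on this read-out higher numbers stand for a stronger effect at the one concentration tested and lower numbers for a weaker effect), compound 1 gives 43%. Compound 2, `Cc1n[nH]c(C(=O)O)c1Cc1cccc(-c2ccc(C(N)=O)cc2)c1`, is measured in this assay at 60%. Compound 3, `Cc1n[nH]c(C(N)=O)c1Cc1cccc(-c2ccc(F)cc2)c1`, reaches 14% in this assay. Among the three numbers compound 1 stands second highest: the nearest is compound 2, a number higher by a margin beyond the scatter, and the furthest is compound 3, a number lower by a margin also beyond the scatter. For the measured compounds named here, no pair of these three differs in a single place, so no single-change step among the measured compounds can be read.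

Compound 4, `Cc1n[nH]c(C(=O)O)c1Cc1ccc(C(=O)O)cc1`, has not yet been measured in this assay. Its change from compound 1 is carboxy in place of phenoxy on an aromatic carbon. Compound 4 keeps the carboxy of compound 1 but gives up the phenoxy with its six-membered aromatic ring of carbon only. Compound 1 and compound 2, both carrying a second aromatic ring on that side of the core, stand higher than compound 3, and nothing measured shows what this core does without such a ring. A downward step beyond the scatter is expected, a number 21 percentage points lower from compound 1 to compound 4 (beyond the scatter). Compound 4 is expected to give 22% in this assay, with a range of 5% to 45%.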

Compound 4, a percentage reported as inhibition, at one concentration (the size of the read-out at that concentration, not a potency): 22%
Compound 4: middle estimate and measured number agree at the digits printed; the measured number falls inside the stated range.
By their numbers in this assay, from the lowest: compounds 3 and 4 (each within the scatter of the next); then compound 1; then compound 2.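

In this assay, for the compounds shown here, carboxy in place of phenoxy on an aromatic carbon, para to a large group, gives a number 21 percentage points lower from compound 1 to compound 4 (beyond the scatter), the first single-change step that can be read; it shows that the read-out depends on which group this position carries. The change takes out the six-membered aromatic ring of carbon only and 7 heavy atoms and brings in 3 heavy atoms with no ring and a hydrogen-bond donor, yet compound 4 still gives 22%, so the step is modest and the read-out does not vanish when that ring leaves. Nothing measured on these compounds accounts for the size of this step.

Going by these compounds alone, the one change removes the ring and adds the carboxy together, so it remains open which of the two events carries the step. Within the data shown here, a methoxy or a plain phenyl at this position, or a primary amide in the place of the carboxy, would separate ring, oxygen link and hydrogen-bond donor, and the single step read here says nothing about any of them.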